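This account rests on a few compounds, and the source may have more. Where it says the series, first, only, none or still open, it means among the compounds named here.

Compound 1, `COc1ccc(C(=O)c2cc(OC)c(OC)c(OC)c2)cc1N`: 60 nM
Compound 2, `COc1ccc(C(=O)c2cc(OC)c(OC)c(OC)c2)cc1NC(=O)/C=C/c1cc(OC)c(OC)c(OC)c1`: 1500 nM

Both compounds were tested in a functional assay on HeLa cells (Homo sapiens) for cytotoxicity, read by MTT assay, with a stated time of 72 h; a lower number here means a stronger inhibitor, a higher number a weaker inhibitor. Compound 1 gives 60 nM. Compound 2, in which the amine carries a cinnamamide, gives 1500 nM, the higher of the two numbers and therefore the weaker inhibitor; the gap to compound 1 lies beyond the scatter. Compound 3, `COc1ccc(C(=O)c2cc(OC)c(OC)c(OC)c2)cc1NC(=O)/C=C/c1ccc(OC)c(OC)c1`, has not yet been measured. It differs from compound 2 in one place: hydrogen in place of methoxy on an aromatic carbon. Among the measured compounds shown here, no pair of measured compounds shows what removing a single methoxy group does on this part of the molecule, so the expectation rests on the change being small relative to the whole structure. The step of a 1.3-fold higher number from compound 2 to compound 3 (0.12 log units; within the scatter) is expected to be small, probably not beyond the scatter, with a slight lean towards a weaker inhibitor. Compound 3 is thus expected to give about 2000 nM in this assay, within a range from 600 nM to 7000 nM.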

Compound 3, half-maximal inhibitory concentration: 7800 nM
The estimate for compound 3 lay 3.9-fold (0.59 log units) below the measured number; measured number above the stated range.
By their numbers in this assay, from the lowest: compound 1; then compound 2; then compound 3.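

In this assay, changing 3,4,5-trimethoxyphenyl to 3,4-dimethoxyphenyl on the cinnamamide gives a 5.2-fold higher number from compound 2 to compound 3 (0.72 log units; beyond the scatter), a move towards a weaker inhibitor. The change swaps one methoxy group for hydrogen, only two heavy atoms in a large molecule, yet this shows that the swap is not a neutral edit at this position and that the third methoxy group counts towards the activity of compound 2. Nothing available here explains why the step has this size.

As far as these compounds go, it remains open whether a hydroxyl group, an amine or a fluorine atom at this place would give a number closer to that of compound 2 or further from it. From the compounds shown here alone, it also remains open whether removing either of the other two methoxy groups on this ring would cost as much.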